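A few compounds are considered here, and "the series" means these few. Any claim that something is new, unique, unknown or untested is made for them only; others in the source may bear on it.

Measured so far in a physicochemical assay for solubility, in phosphate buffer, measured as kinetic solubility, at pH 7.4; on this read-out higher numbers stand for higher solubility and lower numbers for lower solubility:
- compound 1 `COc1cccc(Cl)c1-c1nc(CN2CCC(C(=O)NCCCN3C[C@H](C)C[C@H](C)C3)CC2)c(C)o1`: > 76 ug/mL
- compound 2 `COc1cccc(OC)c1-c1nc(CN2CCC(C(=O)NCCCN3C[C@H](C)C[C@H](C)C3)CC2)c(C)o1`: > 76 ug/mL

The value of compound 2, > 76 ug/mL, is a limit of the assay and not a number. Both values shown sit on this same limit: the limit of > 76 ug/mL in this assay, at which 2 of the 2 values shown sit.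

Compound 3 `COc1ccc(-c2nc(CN3CCC(C(=O)NCCCN4C[C@H](C)C[C@H](C)C4)CC3)c(C)o2)cc1OC` keeps the rest of compound 2 and carries 3,4-dimethoxyphenyl in place of 2,6-dimethoxyphenyl on an aromatic carbon.

Among the measured compounds shown here, the one measured step, a step that the two limits leave unreadable from compound 1 to compound 2, is methoxy in place of chloro on an aromatic carbon, and it gives no size to carry over. On that thin basis, no step beyond the scatter is expected in this assay, and another report as a limit is likely. The expected size is a number no higher from compound 2 to compound 3 (the limit leaves the size open). Compound 3 is estimated at 76 ug/mL, with an expected range of 45 ug/mL to 90 ug/mL.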

Compound 3, solubility: > 76 ug/mL
Compound 3 was reported as a limit; the forecaster's own chance of this, stated with the estimate: 85%; the middle value lies on the limit itself.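

Compound 3, like compound 1 and compound 2, is reported as a limit in this assay, and no new step among the three can be read: the limit of > 76 ug/mL in this assay, at which 3 of the 3 values shown sit.

The compounds shown leave open what number any of the three would give on this read-out, and whether 3,4-dimethoxyphenyl and 2,6-dimethoxyphenyl differ at all.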